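Nitroquinoxaline series: para substituent swap on the anilino ring

This account rests on a few compounds, and the source may have more. Where it says the series, first, only, none or still open, it means among the compounds named here.

Two analogues of the shared core carry a measurement in a functional assay on PC-3 cells (Homo sapiens) for cytotoxicity, read by MTT assay, with a stated time of 96 h; on this read-out lower numbers stand for stronger inhibition and higher numbers for weaker inhibition. For the measured compounds named here, compound 1 `Cc1ccc(NCc2cnc3cc([N+](=O)[O-])ccc3n2)cc1` gives 57000 nM and stands lowest of the two numbers known. Going by the values given here, compound 2 `O=[N+]([O-])c1ccc2nc(CNc3ccc(Cl)cc3)cnc2c1` gives 70000 nM; the one single-point step, a 1.2-fold higher number from compound 1 to compound 2 (0.09 log units; within the scatter), does not separate the two compounds. Compound 3 `CNC(=O)c1ccc(NCc2cnc3cc([N+](=O)[O-])ccc3n2)cc1` has not been measured. It differs from compound 1 in one place: methylcarbamoyl in place of methyl on an aromatic carbon. Among the compounds with values here, no measured step introduces a carbamoyl group, so the only guide is the step from compound 1 to compound 2, which shows that exchanging the group on that aromatic carbon left this assay essentially unchanged. On that basis a step of no more than the scatter is expected, a 1.1-fold higher number from compound 1 to compound 3 (0.02 log units; within the scatter), though the evidence is thin and the range is kept wide. Compound 3 is therefore estimated at 60000 nM, between 25000 nM and 150000 nM.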

Compound 3, half-maximal inhibitory concentration: 49000 nM
For compound 3 the middle estimate is 1.2-fold (0.09 log units) above the measured one; measured number inside the range.
By their numbers in this assay, from the lowest: compounds 3, 1 and 2 (each within the scatter of the next).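

In this assay, methylcarbamoyl in place of methyl gives a 1.2-fold lower number from compound 1 to compound 3 (0.07 log units; within the scatter), and methylcarbamoyl in place of chloro gives a 1.4-fold lower number from compound 2 to compound 3 (0.15 log units; within the scatter). The earlier pair exchanged only methyl and chloro, whereas compound 3 shows that a larger group with a hydrogen-bond donor and a hydrogen-bond acceptor, on this aromatic carbon para to a large group, also stays within the scatter of both neighbours, so the three substituents cannot be told apart here. No supporting measurement bears on why this is so.

Still open, from the compounds shown here alone, is whether an amine, a carboxylic acid or a longer chain at this position would move the number beyond the scatter. Also open, going by these compounds, is whether a change elsewhere on the shared core would do so.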